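Chloro in place of hydrogen, repeated on compound 3

The source may hold more compounds than are shown below. What is called first, only, known or untested is meant among the compounds shown, and "the series" means these compounds.

Measured in a functional assay on MCF7 cells (Homo sapiens) for cytotoxicity, read by sulforhodamine B assay, with a stated time of 72 h; a lower number here means a stronger inhibitor, a higher number a weaker inhibitor:

compound 1 `O=C(Nc1ccc(Nc2ncnc3c2cnn3-c2ccccc2)cc1)Nc1ccccc1Cl` gives 55100 nM
compound 2 `O=C(Nc1ccc(Nc2ncnc3c2cnn3-c2ccc(Cl)cc2)cc1)Nc1ccccc1Cl` gives 9050 nM
compound 3 `O=C(Nc1ccccc1)Nc1ccc(Oc2ncnc3c2cnn3-c2ccccc2)cc1` gives only a limit of the assay, > 100000 nM

Among the compounds with values here, the one change from compound 1 to compound 2, (chloro in place of hydrogen on an aromatic carbon), gave a 6.1-fold lower number from compound 1 to compound 2 (0.78 log units; beyond the scatter). Compound 3 sits at the assay limit, (the limit of > 100000 nM in this assay, at which 1 of the 3 values shown sits), so no number is known for it. How the core of compound 3 differs from the core of compound 1 is not broken down here.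

Compound 4 `O=C(Nc1ccccc1)Nc1ccc(Oc2ncnc3c2cnn3-c2ccc(Cl)cc2)cc1` is not yet measured. Within the data shown here, it differs from compound 3 by chloro in place of hydrogen on an aromatic carbon, the same change as the one from compound 1 to compound 2, at a place described in the same words.

Because the earlier step was a 6.1-fold lower number from compound 1 to compound 2 (0.78 log units; beyond the scatter), a step of similar size is expected for the second pair, an at least 2.5-fold lower number from compound 3 to compound 4 (0.39 log units; beyond the scatter). Going by these compounds, since compound 3 gives only a limit, the starting point is unknown, and compound 4 may still fall at the limit. The estimate for compound 4 in this assay is 40000 nM, within a range expected from 12000 nM to 120000 nM.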

Compound 4, half-maximal inhibitory concentration: 82500 nM
Beside the measured number, compound 4's estimate is 2.1-fold (0.31 log units) below it, and the stated range covers the measured number.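

In this assay, chloro in place of hydrogen on the core of compound 3 gives an at least 1.2-fold lower number from compound 3 to compound 4 (0.08 log units; that floor lies within the scatter), and compound 4 reads as a number at 82500 nM. The step is therefore only a floor: it fits a carry-over of the change from the core of compound 1 to the core of compound 3, but it does not show that the change keeps its size, and the comparison stays unresolved: the same change on two cores in this assay, a 6.1-fold lower number (0.78 log units; beyond the scatter) from compound 1 to compound 2 and an at least 1.2-fold lower number (0.08 log units; that floor lies within the scatter) from compound 3 to compound 4; the limit leaves it open whether they differ The value of compound 3 is a limit and not a number, so the true size of this step stays unknown: the limit of > 100000 nM in this assay, at which 1 of the 4 values shown sits.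

The compounds shown leave open what this change does on a second core where both partners read as numbers, since only one pair gives a step of known size. They also leave open whether the result is particular to chloro, as an amine, a methoxy group or a carboxylic acid in the same place on the phenyl ring could tell.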